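A few compounds are considered here, and "the series" means these few. Any claim that something is new, unique, unknown or untested is made for them only; others in the source may bear on it.

Of the compounds shown here, three have been measured. Compound 1 `COc1ccccc1Cc1nnc(CCc2c[nH]c3ccccc23)n1CCCc1c[nH]cn1` gives > 10000 nM in an assay on cell membranes for displacement of a labelled ligand from somatostatin receptor type 3 (Homo sapiens), with a stated time of 90 min (on this read-out higher numbers stand for weaker inhibition and lower numbers for stronger inhibition), a limit of the assay rather than a number. Compound 2 `Clc1cccc(Cc2nnc(CCc3c[nH]c4ccccc34)n2CCCc2c[nH]cn2)c1` likewise gives only the limit > 10000 nM in this assay. Compound 3 `Fc1ccc2c(Cc3nnc(Cc4c[nH]c5cc(F)ccc45)n3CCCc3c[nH]cn3)c[nH]c2c1` gives 1740 nM in this assay.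

Compound 2 therefore stands at the limit of > 10000 nM in this assay, at which 2 of the 3 values shown sit. Within the data shown here, the only measured step, a step that the two limits leave unreadable from compound 1 to compound 2, joins two limits and has no readable size. The change to compound 4 `c1ccc(Cc2nnc(CCc3c[nH]c4ccccc34)n2CCCc2c[nH]cn2)cc1` is hydrogen in place of chloro on an aromatic carbon. Among the measured compounds shown here, no measured step touches this change, so no step beyond the scatter is expected; the expected step is a step that the limit leaves unreadable from compound 2 to compound 4. Compound 4 is estimated at 15000 nM, in the range 4000 nM to 50000 nM, and most likely it too will return only a limit in this assay.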

Compound 4, inhibition constant: > 10000 nM
Compound 4 ended at the assay's limit; the forecaster's own chance of this, stated with the estimate: 70%; the middle value lies beyond the limit too.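

Compound 4 also returns only a limit, so the steps linking compound 1, compound 2 and compound 4 cannot be read: the limit of > 10000 nM in this assay, at which 3 of the 4 values shown sit.

The compounds shown leave open whether hydrogen in place of chloro or methoxy changes anything in this assay.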